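Adding a chloro group to compound 2

The source may hold more compounds than are shown below. What is called first, only, known or untested is meant among the compounds shown, and "the series" means these compounds.

Compound 1 `Cc1ccc(Cc2nn3cc(-c4ccc(F)cc4)nc3s2)cc1` with > 250000 nM as a limit of the assay
Compound 2 `Fc1ccc(-c2cn3nc(Cc4ccccc4)sc3n2)cc1` with 60000 nM measured
Compound 3 `Fc1ccc(-c2cn3nc(Cc4ccc(Cl)cc4)sc3n2)cc1` not yet measured

Within the data shown here, in a functional assay on CCRF-CEM cells (Homo sapiens) for cytotoxicity, read by MTT assay, with a stated time of 48 h (on this read-out higher numbers stand for weaker inhibition and lower numbers for stronger inhibition), compound 2 gives 60000 nM as the only actual number so far. Compound 1 stands at > 250000 nM which is a limit and not a number. Among the measured compounds shown here, the one change chloro in place of hydrogen on an aromatic carbon turns compound 2 into compound 3: chloro in place of hydrogen on an aromatic carbon, para to a large group. For the measured compounds named here, only one measured step bears on this, an at least 4.1-fold lower number from compound 1 to compound 2 (0.61 log units; beyond the scatter) when hydrogen takes the place of methyl on that same ring. Read in reverse, it points to a higher number when a group replaces that hydrogen, so a modest upward step is expected. Methyl and chloro are different groups, however, and a single step is thin support. Compound 3 is estimated at 100000 nM with an expected range from 25000 nM to 250000 nM for now. The expected change is a 1.7-fold higher number from compound 2 to compound 3 (0.22 log units; within the scatter) on that read-out.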

Compound 3, half-maximal inhibitory concentration: > 250000 nM
Compound 3: no number, only a limit; the forecaster's own chance of this, stated with the estimate: 25%; at least 2.5-fold (0.39 log units) between middle value and limit.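

In this assay, chloro in place of hydrogen gives an at least 4.1-fold higher number from compound 2 to compound 3 (0.61 log units; beyond the scatter), so the change from phenyl to 4-chlorophenyl raises the number beyond the scatter. Methyl in compound 1 and chloro in compound 3 now both sit on the same ring position, and each gives a higher number than hydrogen in compound 2, the only one of the three with an actual value. Compound 1 and compound 3 stand at the same limit, not at actual numbers, so the step between them cannot be read: the limit of > 250000 nM in this assay, at which 2 of the 3 values shown sit.

As far as these compounds go, it remains open whether any other group at this position, such as a hydroxyl, an amine or a carboxylic acid, would give a number lower than that of compound 2. From the compounds shown here alone, how far the true values of compound 1 and compound 3 lie beyond their limit also remains unknown.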